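This account rests on a few compounds, and the source may have more. Where it says the series, first, only, none or still open, it means among the compounds named here.

Working notes on the series.

In a functional assay on SK-MEL-5 cells (Homo sapiens) for cytotoxicity, read by sulforhodamine B assay, with a stated time of 48 h, tested at 0.01 uM (on this read-out lower numbers stand for a stronger effect and higher numbers for a weaker effect at the one concentration tested), compound 1 `COc1ccc(-c2cc(/C=C/C(=O)c3ccc(N)cc3)[nH]n2)cc1` gives 97%, the lowest of the three numbers recorded, but the gap to compound 2 `COc1cc(-c2cc(/C=C/C(=O)c3ccc(Cl)c(Cl)c3)[nH]n2)cc(OC)c1OC` at 98% and to compound 3 `COc1ccc(C(=O)/C=C/c2cc(-c3cc(OC)c(OC)c(OC)c3)n[nH]2)cc1` at 100% stays within the scatter, so no order among the three can be claimed. Among the measured compounds shown here, the one measured step, a number 2 percentage points higher from compound 2 to compound 3 (within the scatter), also sits within the scatter and concerns the aryl on the carbonyl carbon, not the side of the molecule altered here.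

Compound 4 `COc1ccc(-c2cc(/C=C/C(=O)c3ccc(N)cc3)[nH]n2)cc1OC` differs from compound 1 by methoxy in place of hydrogen on an aromatic carbon. For the measured compounds named here, no measured step covers this change; the only guidance is that every variation seen so far in this assay left the read-out essentially unmoved, with all three compounds close to no effect at the tested concentration. A step of no more than the scatter is therefore expected in this assay, in no preferred direction.

Compound 4 is estimated at 98% in this assay, with a range of 91% to 104%, corresponding to an expected step of a number 1 percentage points higher from compound 1 to compound 4 (within the scatter).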

Compound 4, a percentage reported as activity, at one concentration (the size of the read-out at that concentration, not a potency): 99%
For compound 4 the middle estimate is 1 percentage points below the measured one, and the stated range covers the measured number.
By their numbers in this assay, from the lowest: compounds 1, 2, 4 and 3 (each within the scatter of the next).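

Methoxy in place of hydrogen on an aromatic carbon, ortho to a methoxy group and meta to a large group, gives in this assay a step of a number 2 percentage points higher from compound 1 to compound 4 (within the scatter) and is the first measured change on this side of the molecule. At this one concentration, the two compounds cannot be told apart, so the position accepts the added methoxy with no readable consequence, though a read-out close to no effect can say little about any position. No supporting evidence bears on this result.

The compounds shown leave open whether a hydroxy group, a fluorine atom or a longer alkoxy chain at this position would read any differently. They also leave open whether the added methoxy matters under conditions where the series gives a clear effect.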